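This account rests on a few compounds, and the source may have more. Where it says the series, first, only, none or still open, it means among the compounds named here.

Of the compounds shown here, three sharing one core have been measured in an assay for inhibition of Thromboxane-A synthase (Homo sapiens), using microsomes; a higher number here means a weaker inhibitor, a lower number a stronger inhibitor. Compound 1 `CC(C)(Oc1ccccc1F)C1OCC(C/C=C\CCC(=O)O)C(c2cccnc2)O1` gives 45 nM, compound 2 `CC(C)(Oc1ccccc1Br)C1OCC(C/C=C\CCC(=O)O)C(c2cccnc2)O1` gives 29 nM, and compound 3 `COc1ccc(OC(C)(C)C2OCC(C/C=C\CCC(=O)O)C(c3cccnc3)O2)c([N+](=O)[O-])c1` gives 37 nM. Compound 3 thus stands second highest of the three numbers, nearest to compound 1 and furthest from compound 2, with both gaps within the scatter. Compound 4 `CC(C)(Oc1ccc(F)cc1[N+](=O)[O-])C1OCC(C/C=C\CCC(=O)O)C(c2cccnc2)O1` differs from compound 3 by fluoro in place of methoxy on an aromatic carbon. For the measured compounds named here, the steps that bear on this are the aryl exchanges a 1.2-fold lower number from compound 1 to compound 3 (0.09 log units; within the scatter) and a 1.3-fold higher number from compound 2 to compound 3 (0.11 log units; within the scatter), together with the halogen exchange a 1.6-fold lower number from compound 1 to compound 2 (0.19 log units; within the scatter); none of them left the scatter. A step of similar size is therefore expected, no change at the digits printed from compound 3 to compound 4 (within the scatter), with no direction beyond the scatter. Compound 4 is estimated at 37 nM, within a range from 15 nM to 90 nM.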

Compound 4, half-maximal inhibitory concentration: 20 nM
For compound 4 the middle estimate is 1.9-fold (0.27 log units) above the measured one; the range from low to high includes it.
By their numbers in this assay, from the lowest: compounds 4, 2, 3 and 1 (each within the scatter of the next, the first and the last beyond it).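

In this assay, fluoro in place of methoxy on the aromatic carbon meta to a nitro group gives a 1.9-fold lower number from compound 3 to compound 4 (0.27 log units; within the scatter), so this exchange stays inside the scatter, as does the aryl exchange that gives a 1.5-fold lower number from compound 2 to compound 4 (0.16 log units; within the scatter). For the compounds shown here, the aryl exchange that gives a 2.3-fold lower number from compound 1 to compound 4 (0.35 log units; beyond the scatter) is the first step to pass beyond the scatter, though only modestly. Nothing available explains this step. The compounds shown leave open how an amine or a hydroxyl at this same aromatic carbon would read. They also leave open whether the fluoro keeps this standing without the nitro group.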